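The source may hold more compounds than are shown below. What is called first, only, known or untested is meant among the compounds shown, and "the series" means these compounds.

Measured in a functional assay on NCI-H23 cells (Homo sapiens) for inhibition; on this read-out lower numbers stand for stronger inhibition of growth and higher numbers for weaker inhibition of growth:
compound 1 `NS(=O)(=O)c1ccc(/C=C/c2ccc(O)c(O)c2)cc1`: 25900 nM
compound 2 `NS(=O)(=O)c1ccc(/C=C/c2ccc(F)cc2)cc1`: 45100 nM
compound 3 `NS(=O)(=O)c1ccc(/C=C/c2ccc(O)cc2)cc1`: 16900 nM

Compound 3 shares the low end of these three numbers, with its nearest neighbour inside the scatter: a 1.5-fold lower number from compound 1 to compound 3 (0.19 log units; within the scatter). It separates only from the fluoro compound, and modestly: a 2.7-fold lower number from compound 2 to compound 3 (0.43 log units; beyond the scatter).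

Next is compound 4 `CN(C)c1ccc(/C=C/c2ccc(S(N)(=O)=O)cc2)cc1`, with dimethylamino in place of hydroxy on an aromatic carbon, para to a large group: dimethylamino in place of hydroxy on an aromatic carbon.

Among the compounds with values here, no measured compound carries dimethylamino, so the series gives no direct read on this group. The closest evidence is the exchange on the same aromatic carbon, compound 2 against compound 3, which moved the number only modestly (a 2.7-fold lower number from compound 2 to compound 3 (0.43 log units; beyond the scatter)). The loss of the second hydroxy in compound 1 stayed within the scatter (a 1.5-fold lower number from compound 1 to compound 3 (0.19 log units; within the scatter)). On that basis, no step beyond the scatter is expected, with at most a slight rise in the number. The expected step is a 1.2-fold higher number from compound 3 to compound 4 (0.07 log units; within the scatter), and its direction is uncertain.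

For compound 4 the estimated value is 20000 nM, with an expected range from 7000 nM to 50000 nM.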

Compound 4, concentration for 50% growth inhibition: 14200 nM
Estimate against measurement, compound 4: 1.4-fold (0.15 log units) above; low and high end bracket the measured number.
By their numbers in this assay, from the lowest: compounds 4, 3, 1 and 2 (each within the scatter of the next, the first and the last beyond it).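

On the aromatic carbon para to a large group, this assay gives a 1.2-fold lower number from compound 3 to compound 4 (0.08 log units; within the scatter) for dimethylamino in place of hydroxy. This exchange adds heavy atoms and removes the hydrogen-bond donor, yet it leaves the number within the scatter, so a free hydroxy at this carbon is not required to keep compound 4 level with compound 3. The separation from the fluoro compound also carries over to dimethylamino, as a 3.2-fold lower number from compound 2 to compound 4 (0.50 log units; beyond the scatter) remains beyond the scatter but modest, and nothing on hand explains the similarity of the hydroxy and dimethylamino results.

Still open, from the compounds shown here alone, is whether a primary amine or a methoxy group on this carbon would stay at the same level. Also open, going by these compounds, is whether a longer chain on the nitrogen, such as diethylamino, would move the number beyond the scatter.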